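A few compounds are considered here, and "the series" means these few. Any claim that something is new, unique, unknown or untested is made for them only; others in the source may bear on it.

Measured so far in an ADME assay on HepG2 2.2.15 cells (Homo sapiens) for cytotoxicity, read by MTT assay, with stated times of 48 h and 9 days; on this read-out lower numbers stand for higher toxicity in this test and higher numbers for lower toxicity in this test:
compound 1 `COc1ccc(CNC(=O)/C=C/c2coc3cc(O)ccc3c2=O)cc1` gives 718000 nM
compound 2 `COc1ccc2c(=O)c(/C=C/C(=O)Nc3cc(C)ccc3C)coc2c1` gives 1100000 nM
compound 3 `Cc1ccccc1NC(=O)/C=C/c1coc2cc(O)ccc2c1=O` gives 374000 nM

Compound 2 holds the highest of the three numbers in this assay. Compound 1 stands nearest, within the scatter of compound 2, so no order can be read between these two. Compound 3 lies furthest, beyond the scatter, with the lowest number of the three.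

Compound 4 `COc1ccc2c(=O)c(/C=C/C(=O)Nc3ccc(Cl)cc3)coc2c1` has not been measured. It differs from compound 2 in one place: 4-chlorophenyl in place of 2,5-dimethylphenyl on an amide-type nitrogen. Among the compounds with values here, no step between measured compounds covers this change, and the measured amide substituents vary alongside a change on the core, so no direction can be drawn from them. For compound 4 a step of a 1.6-fold lower number from compound 2 to compound 4 (0.20 log units; within the scatter) is expected, within the scatter, with no clear direction. Compound 4 is therefore estimated at 700000 nM, with a range from 250000 nM to 1600000 nM.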

Compound 4, half-maximal cytotoxic concentration: 272000 nM
Compound 4: middle estimate off by 2.6-fold (0.41 log units), on the high side; the range from low to high includes it.
By their numbers in this assay, from the lowest: compounds 4, 3, 1 and 2 (each within the scatter of the next, the first and the last beyond it).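

On the shared core, the group on the amide-type nitrogen moves the number in this assay: 4-chlorophenyl in place of 2,5-dimethylphenyl gives a 4.0-fold lower number from compound 2 to compound 4 (0.61 log units; beyond the scatter), so toxicity in this test is higher with the 4-chlorophenyl group. Within the data shown here, this pair gives the only single-place reading at this position, and it makes the group there a clear contributor to the read-out. No supporting measurement accounts for the shift.

As far as these compounds go, whether the shift tracks the entering chlorine or the departing methyl groups remains open. A morpholine or a carboxylic acid on the same amide-type nitrogen also remains to be placed against these values.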